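The source may report more compounds than this note shows. Statements on the series, on what has been measured and on what is new or still open speak of the compounds shown alone.

Measured compounds and their values:
- Compound 1 `COc1ccccc1NC(=O)Nc1nc2ccc(F)cc2s1`: in a functional assay on NUGC-3 cells (Homo sapiens) for antiproliferative activity, read by sulforhodamine B assay (on this read-out lower numbers stand for stronger inhibition of growth and higher numbers for weaker inhibition of growth), compound 1 gives > 10 ug/mL, a limit of the assay rather than a number.
- Compound 2 `COc1ccc2sc(NC(=O)c3ccc([N+](=O)[O-])cc3)nc2c1`: in this assay compound 2 gives > 10 ug/mL, also a limit.
- Compound 3 `O=C(Nc1nc2ccc(C(F)(F)F)cc2s1)c1ccc([N+](=O)[O-])cc1`: in this assay compound 3 gives > 10 ug/mL, again a limit.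

Compound 1 is therefore not placed on a scale at all: all that is known is that it sits at the limit of this assay, and the same holds for compound 2 and compound 3, as the limit of > 10 ug/mL in this assay, at which 3 of the 3 values shown sit, shows. Within the data shown here, no pair of these three compounds differs in a single place, so no measured step can be traced between them.

The step to compound 4 `O=C(Nc1ccccc1)Nc1nc2ccc(F)cc2s1` is a small one: hydrogen in place of methoxy on an aromatic carbon. Nothing measured here shows what removing the methoxy does to growth inhibition, because the limit of > 10 ug/mL in this assay, at which 3 of the 3 values shown sit, places every value at the limit. Among the measured compounds shown here, with no step of known size to lean on, the expectation is that the change from compound 1 to compound 4 is, at most, a step that the limit leaves unreadable from compound 1 to compound 4 and that compound 4 most likely also reaches only the limit. The estimate for compound 4 in this assay is 15 ug/mL, with a range from 4 ug/mL to 60 ug/mL.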

Compound 4, concentration for 50% growth inhibition: > 10 ug/mL
Compound 4: a limit, no number; the forecaster's own chance of this, stated with the estimate: 75%; the middle value is on the limit's open side.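

In this assay, compound 4 and compound 1 both give only a limit, so no step can be read between them, because the values shown offer no number to compare: the limit of > 10 ug/mL in this assay, at which 4 of the 4 values shown sit.

The compounds shown leave open how strongly any of them inhibits growth, and whether hydrogen in place of methoxy changes that at all.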